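A few compounds are considered here, and "the series" means these few. Any claim that something is new, unique, unknown or untested is made for them only; others in the source may bear on it.

Measured compounds:
- Compound 1 `Cc1cc(C)cc(CNC(=O)CN(CCCCCC(=O)Nc2ccccc2N)C(=O)c2cc(C)cc(C)c2)c1`: in an assay on Sf9 cells for inhibition of protein deacetylase HDAC6 (Homo sapiens), read by fluorescence, with a stated time of 90 min (on this read-out lower numbers stand for stronger inhibition and higher numbers for weaker inhibition), compound 1 gives > 10000 nM, which is a limit of the assay rather than a number.
- Compound 2 `Cc1cc(C)cc(C(=O)N(CC(=O)NCc2ccccc2)Cc2ccc(C(=O)Nc3cc(F)ccc3N)cc2)c1`: in this assay compound 2 gives > 10000 nM, again only a limit.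
- Compound 3 `CN(C)c1ccc(C(=O)N(CC(=O)NCc2ccccc2)Cc2ccc(C(=O)Nc3ccccc3N)cc2)cc1`: in this assay compound 3 gives > 10000 nM, also a limit.

Among the compounds with values here, compound 3 therefore stands nowhere in particular: the only number recorded for it is a limit, and the same holds for compound 1 and compound 2, as the limit of > 10000 nM in this assay, at which 3 of the 3 values shown sit, shows. No ordering among the three can be drawn, and nothing separates compound 3 from the other two.

Compound 4 `Nc1ccccc1NC(=O)c1ccc(CN(CC(=O)NCc2ccccc2)C(=O)c2cccnc2)cc1` has not been measured in this assay. It differs from compound 3 in one place: pyridin-3-yl in place of 4-(dimethylamino)phenyl on a carbonyl carbon. Within the data shown here, the series gives no measured step to set this change against, since no two measured compounds differ in a single place. With compound 3 at a limit, there is no base number from which a step could be counted. The step is expected to be none beyond the scatter, a step that the limit leaves unreadable from compound 3 to compound 4. Compound 4 is thus estimated at 15000 nM, with a range from 4000 nM to 60000 nM, and the most likely outcome is that the assay again reports only a limit.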

Compound 4, half-maximal inhibitory concentration: > 10000 nM
Compound 4: no number, only a limit; the forecaster's own chance of this, stated with the estimate: 80%; the middle value does not contradict the limit.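

No step can be read from compound 3 to compound 4, since both compounds stand only at a limit: the limit of > 10000 nM in this assay, at which 4 of the 4 values shown sit.

The compounds shown leave open how far pyridin-3-yl and 4-(dimethylamino)phenyl differ in this assay, and whether any single change to this series gives a number rather than a limit.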